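Swapping the imidazolyl group for a methylated carboxamide

This account rests on a few compounds, and the source may have more. Where it says the series, first, only, none or still open, it means among the compounds named here.

Measured compounds:
- compound 1 `Brc1nn(-c2ccc3ncccc3c2)c2nc(N[C@@H]3CC[C@@H](c4ncc[nH]4)C3)ncc12`, an assay on SK-OV-3 cells for inhibition of eIF-2-alpha kinase GCN2 (Homo sapiens); a higher number here means a weaker inhibitor, a lower number a stronger inhibitor: 545 nM
- compound 2 `COCCS(=O)(=O)N[C@@H]1CC[C@@H](Nc2ncc3c(Br)nn(-c4ccc5ncccc5c4)c3n2)C1`, this assay: 262 nM

Compound 1 stands at the highest of the two numbers, that is, the weaker of the two inhibitors. Its nearest neighbour is compound 2, reached by a 2.1-fold lower number from compound 1 to compound 2 (0.32 log units; beyond the scatter), a step that follows from putting a ((2-methoxyethyl)sulfonyl)amino group in place of the 1H-imidazol-2-yl group on a saturated ring carbon.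

Compound 3 `CNC(=O)[C@]1(C)CC[C@@H](Nc2ncc3c(Br)nn(-c4ccc5ncccc5c4)c3n2)C1` is not yet measured. Its change from compound 1 is a group of 10 heavy atoms (8 carbon, 1 nitrogen, 1 oxygen; one five-membered non-aromatic ring of carbon only) in place of a group of 10 heavy atoms (8 carbon, 2 nitrogen; one five-membered non-aromatic ring of carbon only, one five-membered aromatic ring with 2 hetero atoms), on a nitrogen on an aromatic ring, on a nitrogen on an aromatic ring whose other neighbours are an aromatic carbon; the imidazolyl group leaves and an amide-bearing, methylated ring enters. Among the measured compounds shown here, only the step from compound 1 to compound 2 bears on this, and it was modest; it too removed the imidazolyl group from that ring. A step of similar size and direction is therefore expected here, though with some uncertainty because a single comparison underlies it.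

Compound 3 is expected to give 350 nM in this assay, within 150 nM to 900 nM, which amounts to an estimated 1.6-fold lower number from compound 1 to compound 3 (0.19 log units; within the scatter).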

Compound 3, half-maximal inhibitory concentration: 21 nM
Estimate against measurement, compound 3: 17-fold (1.22 log units) above, and the stated range ends above it.
By their numbers in this assay, from the lowest: compound 3; then compound 2; then compound 1.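

In this assay, the group on a nitrogen on an aromatic ring proves far more responsive than the earlier pair suggested: the amide-bearing, methylated ring gives a 26-fold lower number from compound 1 to compound 3 (1.41 log units; beyond the scatter), whereas the ((2-methoxyethyl)sulfonyl)amino change gave only a 2.1-fold lower number from compound 1 to compound 2 (0.32 log units; beyond the scatter). Both changes remove the imidazolyl group, yet one step is modest and the other large, so the loss of that group alone does not set the size of the step; what enters also counts, and compound 3 has the lowest number of the three. Nothing available here accounts for the size of this step.

The entering group differs from the old one in more than one feature, carrying both a methyl group on the saturated ring and a methylated carboxamide, so the compounds shown cannot separate what each contributes. Also open, on these data alone, is how the same ring would read without that ring methyl group, or with a primary carboxamide, a carboxylic acid or an amine in place of the methylated carboxamide.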